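Swapping a trifluoromethylphenyl for a dimethoxyphenyl

The compounds below may be only part of what the source reports. "The series", "measured", "known", "first", "only" and "open" are said of these compounds alone.

Measured so far in a functional assay on MCF7 cells (Homo sapiens) for antiproliferative activity, read by MTT assay, with a stated time of 24 h; a lower number here means a stronger inhibitor, a higher number a weaker inhibitor:
Compound 1 `COc1ccc(C2CC(c3ccccc3)=NN2c2ccc(-c3ccccc3)nn2)c(OC)c1` gives > 100000 nM, which is a limit of the assay and not a number.
Compound 2 `Fc1ccc(C2CC(c3ccc(Cl)cc3)=NN2c2ccc(-c3ccccc3)nn2)cc1` gives 3750 nM.
Compound 3 `FC(F)(F)c1ccc(C2CC(c3ccc(Cl)cc3)=NN2c2ccc(-c3ccccc3)nn2)cc1` gives 1670 nM.

Among the measured compounds shown here, compound 3 holds the lowest of the two numbers that were read in this assay; the only other number, from compound 2, sits a 2.2-fold lower number from compound 2 to compound 3 (0.35 log units; beyond the scatter). Compound 1 shows only a limit, (the limit of > 100000 nM in this assay, at which 1 of the 3 values shown sits).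

The next compound, compound 4 `COc1ccc(C2CC(c3ccc(Cl)cc3)=NN2c2ccc(-c3ccccc3)nn2)c(OC)c1`, keeps the 4-chlorophenyl and the shared core of compound 3 and changes one place: 2,4-dimethoxyphenyl in place of 4-(trifluoromethyl)phenyl on a saturated ring carbon. For the measured compounds named here, none of the measured steps covers this exchange directly; the one step that was measured, a 2.2-fold lower number from compound 2 to compound 3 (0.35 log units; beyond the scatter), concerns a different swap on the same ring and was modest. What bears on the expectation is compound 1, which also carries the 2,4-dimethoxyphenyl and sits at the limit > 100000 nM. Compound 4 is therefore expected to give a much higher number in this assay than compound 3, an estimated step of a 15-fold higher number from compound 3 to compound 4 (1.18 log units; beyond the scatter). The estimate for compound 4 is 25000 nM, within a range from 5000 nM to 100000 nM, with a real chance that only a limit is reported.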

Compound 4, half-maximal inhibitory concentration: > 100000 nM
Compound 4: a limit, no number; the forecaster's own chance of this, stated with the estimate: 40%; at least 4.0-fold (0.60 log units) between middle value and limit.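

In this assay, with the 4-chlorophenyl kept, the change on this saturated ring carbon gives an at least 59-fold higher number from compound 3 to compound 4 (1.77 log units; beyond the scatter) when 2,4-dimethoxyphenyl replaces 4-(trifluoromethyl)phenyl, and an at least 26-fold higher number from compound 2 to compound 4 (1.42 log units; beyond the scatter) when it replaces 4-fluorophenyl. The earlier compounds shown here showed only a 2.2-fold lower number from compound 2 to compound 3 (0.35 log units; beyond the scatter) at this position, so the position is now seen to respond far more strongly to one exchange than to another. The step between compound 1 and compound 4 cannot be read, as both ends are limits and not numbers, so the chloro has no measurable effect here, and the 4-chlorophenyl does not bring back a readable number when 2,4-dimethoxyphenyl is present: the limit of > 100000 nM in this assay, at which 2 of the 4 values shown sit.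

Going by these compounds, it remains open whether a single methoxy group on this phenyl ring would lead to the same loss, and whether a hydroxyl or an amine on that ring would keep a readable number. On these data alone, how far compound 4 lies past its limit also remains unknown, so the true size of its steps is open.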